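Ethyl to Propyl Carbamate on a Pyrrolidine Series

The source may hold more compounds than are shown below. What is called first, only, known or untested is meant among the compounds shown, and "the series" means these compounds.

Measured compounds:
compound 1, `COc1ccc(C[C@@H]2[C@H](OC(=O)N3CCN(C)CC3)[C@@H](O)CN2C(=O)c2cc(-c3ccc(Cl)cc3)oc2C(F)(F)F)cc1`, 10000 nM
compound 2, `CCOC(=O)N1C[C@H](O)[C@@H](OC(=O)NCc2ccccc2-c2ccccc2)[C@H]1Cc1ccc(OC)cc1`, 22000 nM

In a functional assay on HEK293 cells (Homo sapiens) for inhibition (on this read-out lower numbers stand for stronger inhibition and higher numbers for weaker inhibition), compound 2 gives 22000 nM. This is the higher of the two numbers seen, and the nearest neighbour is compound 1, which in this assay gives 10000 nM; the gap between them lies beyond the scatter, so compound 2 is the weaker of the two. Compound 3, `CCCOC(=O)N1C[C@H](O)[C@@H](OC(=O)NCc2ccccc2-c2ccccc2)[C@H]1Cc1ccc(OC)cc1`, has not been measured. It differs from compound 2 in one place: methyl in place of hydrogen on a saturated chain carbon, two bonds along the chain from an oxygen next to a carbonyl group. Among the measured compounds shown here, no measured pair shows this change, so its size is unknown from the data. Since the chain grows by one carbon only, the step from compound 2 to compound 3 in this assay is expected to be small, in either direction or none beyond the scatter, estimated as a 1.2-fold lower number from compound 2 to compound 3 (0.09 log units; within the scatter). Compound 3 is therefore expected to give about 18000 nM in this assay, within a range from 7000 nM to 50000 nM.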

Compound 3, half-maximal inhibitory concentration: 9000 nM
Estimate against measurement, compound 3: 2.0-fold (0.30 log units) above; measured number inside the range.
By their numbers in this assay, from the lowest: compounds 3 and 1 (each within the scatter of the next); then compound 2.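

In this assay, going from ethoxy to propoxy on the shared core gives a step beyond the scatter (a 2.4-fold lower number from compound 2 to compound 3 (0.39 log units; beyond the scatter)), so this position responds to one added methyl on a saturated chain carbon, two bonds along the chain from an oxygen next to a carbonyl group. Among the compounds shown here, this is the only measured pair differing in one place, and it shows that the change from ethyl to propyl moves the number toward stronger inhibition rather than leaving it unchanged. No measurement at hand accounts for this step.

Going by these compounds, whether the trend carries on to a butyl group or a longer chain, or holds for a branched isopropyl group, remains open. On these data alone, it is also open whether an amine at the end of the chain would keep the step.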